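Bromo in Place of Methoxy: A One-Step Forecast

The source may report more compounds than this note shows. Statements on the series, on what has been measured and on what is new or still open speak of the compounds shown alone.

Measured compounds:
Compound 1, `C[C@H](NC(=O)Nc1ccccc1C(C)(C)C)c1ccccc1`: in an ADME assay on the whole organism with Oryza sativa as the target, tested at 1 uM (on this read-out lower numbers stand for a stronger effect and higher numbers for a weaker effect at the one concentration tested), compound 1 gives 99%.
Compound 2, `COc1ccccc1NC(=O)N[C@@H](C)c1ccccc1`: in this assay compound 2 gives 99%.

Compound 2 stands level with compound 1. Going by the values given here, the one measured step, no change at the digits printed from compound 1 to compound 2 (within the scatter), lies within the scatter, so replacing tert-butyl by methoxy on an aromatic carbon left the reading where it was. Both readings sit near the top of the scale, which on this read-out means a weak effect at the single concentration tested.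

Compound 3, `C[C@H](NC(=O)Nc1ccccc1Br)c1ccccc1`, is not yet measured. It differs from compound 2 by bromo in place of methoxy on an aromatic carbon. Among the compounds with values here, only the step from compound 1 to compound 2 bears on this change, and it shows that one exchange at this aromatic carbon made no difference beyond the scatter. With a single such precedent, the expectation for compound 3 is another flat step, a number 1 percentage points lower from compound 2 to compound 3 (within the scatter), with no movement beyond the scatter. Compound 3 is therefore estimated at 98%, with a range from 85% to 105%.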

Compound 3, a percentage reported as activity, at one concentration (the size of the read-out at that concentration, not a potency): 99%
Beside the measured number, compound 3's estimate is 1 percentage points below it, and the stated range covers the measured number.
By their numbers in this assay, from the lowest: compounds 1, 2 and 3 (each within the scatter of the next).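

In this assay, exchanging methoxy for bromo gives a step that stays inside the usual variation between repeat measurements (no change at the digits printed from compound 2 to compound 3 (within the scatter)), and the same holds when tert-butyl and bromo are compared directly (no change at the digits printed from compound 1 to compound 3 (within the scatter)). This aromatic carbon has now carried three different groups with no reading separated from the others, and the latest exchange swaps a group of carbon and oxygen, with one hydrogen-bond acceptor, for a single bromine atom with none. So the flat result seen earlier is not confined to one pair of groups, although all three compounds stay at the weak end of the scale, where a flat result says little about what this position could do in a more active compound. No supporting measurement explains this lack of movement.

Going by these compounds, whether an amine, a carboxylic acid or a longer chain on this same aromatic carbon would shift the reading remains open. Also open, on these data alone, is whether changes elsewhere on the shared core would move the reading, and whether the three compounds would stay level at another concentration.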